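Oxadiazole in Place of Methylamide on a Shared Core

The compounds below may be only part of what the source reports. "The series", "measured", "known", "first", "only" and "open" are said of these compounds alone.

Compound 1 `CC(C)(C)OC(=O)CN1CCc2c(sc(NC(=O)Nc3ccc(Cl)cc3)c2C(N)=O)C1`: > 25000 nM
Compound 2 `CCN1CCc2c(sc(NC(=O)Nc3ccc(Cl)cc3)c2C(=O)NC)C1`: > 25000 nM
Compound 3 `CC(C)(C)OC(=O)CCN1CCc2c(sc(NC(=O)Nc3ccc(Cl)cc3)c2C(N)=O)C1`: 1100 nM

In a functional assay (strain AB) with Danio rerio as the target, read by microscopy, with a stated time of 1 h (a lower number here means that less compound is needed, a higher number that more compound is needed for the effect), compound 2 gives only a limit, > 25000 nM. Compound 2 thus stands at the limit of > 25000 nM in this assay, at which 2 of the 3 values shown sit. Compound 1 also reaches only a limit, > 25000 nM. Compound 3 gives a number, 1100 nM. Among the measured compounds shown here, the single measured step, an at least 22-fold lower number from compound 1 to compound 3 (1.35 log units; beyond the scatter), concerns the chain on the ring nitrogen and not the carbonyl, so no measured step bears on the change now considered. Compound 4 `CCN1CCc2c(sc(NC(=O)Nc3ccc(Cl)cc3)c2C(=O)c2nc(C)no2)C1` differs from compound 2 at the carbonyl: 3-methyl-1,2,4-oxadiazol-5-yl in place of methylamino on a carbonyl carbon. With nothing measured at this place, the direction is open. Compound 4 is estimated at 15000 nM, with a range of 2000 nM to 50000 nM. This corresponds to an expected at least 1.6-fold lower number from compound 2 to compound 4 (0.22 log units; that floor lies within the scatter).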

Compound 4, half-maximal effective concentration: > 25000 nM
Compound 4: only a limit was reported (the forecaster's own chance of this, stated with the estimate: 55%); middle value at least 1.6-fold (0.22 log units) from the limit.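

In this assay, compound 2 and compound 4 both give only a limit, so the step between them cannot be read. The compounds shown leave open whether 3-methyl-1,2,4-oxadiazol-5-yl in place of methylamino on a carbonyl carbon changes the number at all.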